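Adding chloro to a furan chalcone: the expected cytotoxicity

A few compounds are considered here, and "the series" means these few. Any claim that something is new, unique, unknown or untested is made for them only; others in the source may bear on it.

Of the compounds shown here, three have been measured in a functional assay on HeLa cells (Homo sapiens) for inhibition, read by MTT assay, with a stated time of 48 h; on this read-out higher numbers stand for weaker inhibition and lower numbers for stronger inhibition. Compound 1 `O=C(/C=C/c1cc([N+](=O)[O-])ccc1Cl)c1ccc[nH]1` gives 68000 nM in this assay. Compound 2 `O=C(/C=C/c1ccccc1Cl)c1ccco1` gives 26000 nM. Compound 3 `O=C(/C=C/c1cccc([N+](=O)[O-])c1)c1ccco1` gives 22000 nM, the lowest of the three numbers; its gap to compound 2 lies within the scatter, while compound 1 stands beyond the scatter above it. Compound 4 `O=C(/C=C/c1cc([N+](=O)[O-])ccc1Cl)c1ccco1` has not yet been measured; it differs from compound 3 by chloro in place of hydrogen on an aromatic carbon. Within the data shown here, no pair of measured compounds isolates this change, so its size is unknown. Compound 4 is expected to stay near compound 3, with the step of a 1.4-fold higher number from compound 3 to compound 4 (0.13 log units; within the scatter) not expected to exceed the scatter by much in either direction. The estimate for compound 4 in this assay is 30000 nM, within 12000 nM to 75000 nM.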

Compound 4, half-maximal inhibitory concentration: > 100000 nM
Compound 4 gave a limit, no number; the forecaster's own chance of this, stated with the estimate: 10%; middle value at least 3.3-fold (0.52 log units) away from the limit.
By their numbers in this assay, from the lowest: compounds 3 and 2 (each within the scatter of the next); then compound 1. At a limit, above all of these: compound 4.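

In this assay, among these compounds, chloro in place of hydrogen on this aromatic carbon, para to a nitro group, is the first change here whose size can be bounded, giving an at least 4.5-fold higher number from compound 3 to compound 4 (0.65 log units; beyond the scatter), a step that is at least modest. Nitro in place of hydrogen gives an at least 3.8-fold higher number from compound 2 to compound 4 (0.58 log units; beyond the scatter), also at least modest, so on the furan compounds each group, added to the other, weakens inhibition. Both steps are floors, as compound 4 stands at a limit and not at a number: the limit of > 100000 nM in this assay, at which 1 of the 4 values shown sits.

Furan-2-yl in place of 1H-pyrrol-2-yl on a carbonyl carbon gives an at least 1.4-fold higher number from compound 1 to compound 4 (0.16 log units; that floor lies within the scatter), so this step cannot be read. On these data alone, whether an amine or a methoxy group on this carbon would stay near compound 3 remains open.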